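Swapping the Aryl Urea End of Compound 3

The source may hold more compounds than are shown below. What is called first, only, known or untested is meant among the compounds shown, and "the series" means these compounds.

Values in a functional assay on SW-620 cells (Homo sapiens) for inhibition, read by MTT assay, with a stated time of 72 h (on this read-out lower numbers stand for stronger inhibition and higher numbers for weaker inhibition), are:
- compound 1 `COc1cc(NC(C)CCCNC(=O)NNC(=O)Nc2ccc(Cl)cc2)c2ncccc2c1` gives 48000 nM
- compound 2 `COc1cc(NC(C)CCCNC(=O)Nc2cccc(O)c2)c2ncccc2c1` gives 27000 nM
- compound 3 `COc1cc(NC(C)CCCNC(=O)NNC(=O)Nc2cccc(F)c2)c2ncccc2c1` gives 9500 nM

Compound 3 has the lowest number of the three, which makes it the strongest inhibitor measured so far. The closest comparison is a 2.8-fold lower number from compound 2 to compound 3 (0.45 log units; beyond the scatter).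

The next compound to be tested is compound 4 `COc1cc(NC(C)CCCNC(=O)Nc2ccc(Cl)cc2)c2ncccc2c1`. It has 4-chlorophenyl in place of ((3-fluorophenyl)carbamoyl)amino on an amide-type nitrogen.

Among the measured compounds shown here, no measured step makes exactly this change, so two indirect steps must serve. Compound 4 shares the 4-chlorophenyl group with compound 1, and the step that separates the two halogen-bearing compounds is a 5.1-fold lower number from compound 1 to compound 3 (0.70 log units; beyond the scatter). This suggests that giving up 3-fluorophenyl may cost some inhibition. Compound 4 also lacks the carbamoylamino link, as compound 2 does, and the step that removes it, while also changing the ring, is only a 1.8-fold lower number from compound 1 to compound 2 (0.25 log units; within the scatter). Together these point to a modest change towards a higher number in this assay. The expected step is a 2.1-fold higher number from compound 3 to compound 4 (0.32 log units; beyond the scatter).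

For compound 4 the estimated value is 20000 nM, with an expected range of 6000 nM to 60000 nM.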

Compound 4, half-maximal inhibitory concentration: 28000 nM
Compound 4: the middle estimate sits 1.4-fold (0.15 log units) below what was measured, and the stated range covers the measured number.
By their numbers in this assay, from the lowest: compound 3; then compounds 2, 4 and 1 (each within the scatter of the next).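

In this assay, replacing the whole ((3-fluorophenyl)carbamoyl)amino end with 4-chlorophenyl on the amide-type nitrogen gives a 2.9-fold higher number from compound 3 to compound 4 (0.47 log units; beyond the scatter), a step beyond the scatter that leaves compound 3 as the strongest inhibitor of the four. When 4-chlorophenyl is present in both compounds and only the carbamoylamino link goes, the result is a 1.7-fold lower number from compound 1 to compound 4 (0.23 log units; within the scatter), so removing that link makes no change that can be told from the scatter in this pair. The two shorter ends also cannot be told apart, since 4-chlorophenyl in place of 3-hydroxyphenyl gives a 1.0-fold higher number from compound 2 to compound 4 (0.02 log units; within the scatter), which means that at this position the assay does not separate the chloro-substituted ring from the hydroxy-substituted one.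

Nothing available here explains the size of any of these steps. The compounds shown leave open whether the advantage of compound 3 comes from the 3-fluorophenyl ring alone or from that ring together with the carbamoylamino link, and how a 3-fluorophenyl or a 3-aminophenyl group placed directly on the amide-type nitrogen would compare.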